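The source may report more compounds than this note shows. Statements on the series, on what has been measured and on what is new or still open speak of the compounds shown alone.

In an ADME assay on CCRF-HSB-2 cells (Homo sapiens) for cytotoxicity, with a stated time of 7 days (a lower number here means that less compound is tolerated, a higher number that more compound is tolerated), three compounds sharing one core have been read so far. Compound 1 `Nc1nc(OCc2ccccc2)c2ncn(/C=C3/CC3(CO)CO)c2n1` gives > 20000 nM, which is a limit of the assay and not a number. Compound 2 `CCCCCCCCSc1nc(N)nc2c1ncn2/C=C1/CC1(CO)CO` gives 60000 nM. Compound 3 `CCCCCCSc1nc(N)nc2c1ncn2/C=C1/CC1(CO)CO` gives 60000 nM, which places it level with compound 2. Shortening octylsulfanyl to hexylsulfanyl thus leaves no change at the digits printed from compound 2 to compound 3 (within the scatter). The comparisons with the benzyloxy compound yield only a step that the limit leaves unreadable from compound 1 to compound 2 and a step that the limit leaves unreadable from compound 1 to compound 3.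

Compound 4 `CCCCOc1nc(N)nc2c1ncn2/C=C1/CC1(CO)CO` carries butoxy in place of hexylsulfanyl on an aromatic carbon. No readable measured step exchanges a sulfur-linked chain for an oxygen-linked one. Among the measured compounds shown here, the sole readable step is no change at the digits printed from compound 2 to compound 3 (within the scatter), and it concerns chain length alone, so it offers no reason to expect a shift in either direction. The expected result is a 1.2-fold lower number from compound 3 to compound 4 (0.08 log units; within the scatter), with no move beyond the scatter. For compound 4, the estimated value in this assay is 50000 nM, with an expected range of 20000 nM to 100000 nM.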

Compound 4, half-maximal cytotoxic concentration: > 20000 nM
Compound 4: only a limit was reported; the forecaster's own chance of this, stated with the estimate: 45%; the middle value lies beyond the limit too.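

In this assay, compound 4 gives only a limit, > 20000 nM, so no step between it and compound 1, compound 2 or compound 3 can be read: the limit of > 20000 nM in this assay, at which 2 of the 4 values shown sit.

The compounds shown leave open whether butoxy in place of hexylsulfanyl shifts the tolerated concentration at all.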